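A few compounds are considered here, and "the series" means these few. Any claim that something is new, unique, unknown or untested is made for them only; others in the source may bear on it.

In a functional assay on SW480 cells (Homo sapiens) for inhibition (on this read-out lower numbers stand for stronger inhibition and higher numbers for weaker inhibition), compound 1 `COc1cc[nH]c1/C=C1\C(=O)Nc2ccc(F)c(C#CC(O)CN)c21` gives 110 nM, compound 2 `COc1cc[nH]c1/C=C1\C(=O)Nc2ccc(F)c(C#C[C@H](N)CO)c21` gives 270 nM and compound 3 `CN[C@H](C#Cc1c(F)ccc2c1/C(=C/c1[nH]ccc1OC)C(=O)N2)CO` gives 100 nM. Compound 3 sits at the low end of this short series and shares that place with compound 1, from which the scatter does not separate it. Compound 4 `COc1cc[nH]c1/C=C1\C(=O)Nc2ccc(F)c(C#C[C@@H](NS(C)(=O)=O)[C@@H](C)O)c21` keeps the shared core and alters only the group on a triple-bonded carbon, with 2-hydroxy-1-(methanesulfonamido)propyl in place of 2-hydroxy-1-(methylamino)ethyl (2-hydroxy-1-(methanesulfonamido)propyl in place of 2-hydroxy-1-(methylamino)ethyl on a triple-bonded carbon).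

All three measured steps alter this same group. One stays within the scatter, a 1.1-fold lower number from compound 1 to compound 3 (0.04 log units; within the scatter), and two are modest, a 2.5-fold higher number from compound 1 to compound 2 (0.39 log units; beyond the scatter) and a 2.7-fold lower number from compound 2 to compound 3 (0.43 log units; beyond the scatter). For the measured compounds named here, none of the measured compounds carries a methanesulfonamido group, so these steps guide the expectation only loosely, and the change here is larger than any of them. The one move away from the low end, a 2.5-fold higher number from compound 1 to compound 2 (0.39 log units; beyond the scatter), suggests that a modest rise in this assay is the likeliest outcome, though a result within the scatter would not be surprising. The expected change is a 1.8-fold higher number from compound 3 to compound 4 (0.26 log units; within the scatter). Compound 4 is estimated at 180 nM, with an expected range of 50 nM to 650 nM.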

Compound 4, half-maximal inhibitory concentration: 1190 nM
Compound 4: middle estimate off by 6.6-fold (0.82 log units), on the low side, and the stated range ends below it.
By their numbers in this assay, from the lowest: compounds 3 and 1 (each within the scatter of the next); then compound 2; then compound 4.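

In this assay, for the compounds shown here, the group on a triple-bonded carbon proves able to carry much larger changes than the earlier compounds showed: 2-hydroxy-1-(methanesulfonamido)propyl gives a 12-fold higher number from compound 3 to compound 4 (1.08 log units; beyond the scatter) and an 11-fold higher number from compound 1 to compound 4 (1.03 log units; beyond the scatter), both large, along with a 4.4-fold higher number from compound 2 to compound 4 (0.64 log units; beyond the scatter), which is modest. Going by these compounds alone, the earlier steps at this place were at most modest, and compound 4 is the only compound whose number lies beyond the scatter of all three others, on the high side. The entering group brings in sulfur, further oxygen and a second defined stereocentre, but no measurement shown ties the rise to any of these features or gives a reason for it.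

Compound 4 alters the substituent on the nitrogen and the length of the chain at once, so these compounds cannot separate the effect of the methanesulfonamido group from that of the longer propyl chain. As far as these compounds go, what a free amine on the same propyl chain, or an acetamide in place of the methanesulfonamide on the shorter chain, would give at this place remains open.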